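A few compounds are considered here, and "the series" means these few. Any claim that something is new, unique, unknown or untested is made for them only; others in the source may bear on it.

Of the compounds shown here, two of a shared core have been measured in a functional assay on SK-BR-3 cells (Homo sapiens) for antiproliferative activity, read by MTT assay, with a stated time of 72 h; a higher number here means a weaker inhibitor, a lower number a stronger inhibitor. Compound 1 `Cc1cc(N2CCCC2)nc2ccc(NC(=O)c3ccc(Cl)c(Cl)c3)cc12` gives 43400 nM in this assay. Compound 2 `CCc1ccccc1C(=O)Nc1ccc2nc(N3CCN(CC)CC3)cc(C)c2c1` gives 23900 nM in this assay; this is the lower of the two numbers, but the gap to compound 1 is within the scatter, so the two compounds cannot be told apart on these data.

Compound 3 `CCN1CCN(c2cc(C)c3cc(NC(=O)c4ccc(OC)cc4)ccc3n2)CC1` has not yet been measured in this assay. It differs from compound 2 in one place: 4-methoxyphenyl in place of 2-ethylphenyl on a carbonyl carbon. For the measured compounds named here, no measured pair with the same change is available, so the size of the step rests only on the two values known. With compound 1 and compound 2 sitting within the scatter of each other, compound 3 is expected to stay in the same region, and the step of a 1.0-fold higher number from compound 2 to compound 3 (0.02 log units; within the scatter) is expected to be none beyond the scatter. Compound 3 is therefore estimated at 25000 nM in this assay, with a range from 8000 nM to 80000 nM.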

Compound 3, half-maximal inhibitory concentration: 9000 nM
Compound 3: middle estimate off by 2.8-fold (0.44 log units), on the high side, within the range that was stated.
By their numbers in this assay, from the lowest: compound 3; then compounds 2 and 1 (each within the scatter of the next).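

In this assay, the group on this carbonyl carbon does affect the read-out: 4-methoxyphenyl in place of 2-ethylphenyl gives a 2.7-fold lower number from compound 2 to compound 3 (0.42 log units; beyond the scatter), a modest step but one beyond the scatter. The earlier compounds shown here could not show this, as they differ in more than one place and sit within the scatter of each other. The entering and leaving groups have the same heavy-atom count, while the entering group brings an oxygen and a hydrogen-bond acceptor, but nothing available explains the step.

The pair leaves open whether the lower number goes with gaining the methoxy group or losing the ethyl group, as both changes occur together. A plain phenyl on the same carbonyl carbon would help to separate the two, but the compounds shown do not include one.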